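The source may report more compounds than this note shows. Statements on the series, on what has been measured and on what is new or still open speak of the compounds shown alone.

Measured so far in an ADME assay on microsomes from liver (Homo sapiens) for metabolic stability, read by LC-MS, with a stated time of 10 min; a higher number here means that more of the compound is left, a lower number that less of the compound is left:
Compound 1 `c1cnc2c(c1)CCC[C@@H]2N(CC1CC1)C[C@H]1Cc2c(cccc2N2CCNCC2)CN1` gives 82.1%
Compound 2 `CN(C[C@H]1Cc2c(cccc2N2CCN(c3cccc(C(F)(F)F)c3)CC2)CN1)[C@H]1CCCc2cccnc21` gives 90.3%
Compound 3 `CN1CCN(c2cccc3c2C[C@H](CN(C)[C@H]2CCCc4cccnc42)NC3)CC1` gives 75.8%

Compound 1 sits within the usual scatter of both compound 2 and compound 3, so it cannot be ranked against either. The next compound, compound 4 `c1cnc2c(c1)CCC[C@@H]2N(CC1CCCCC1)C[C@H]1Cc2c(cccc2N2CCNCC2)CN1`, keeps the core of compound 1 and alters one group. The change cyclohexyl in place of cyclopropyl on a saturated chain carbon bound to an amine nitrogen puts cyclohexyl in place of cyclopropyl on a saturated chain carbon bound to an amine nitrogen.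

Going by the values given here, only one measured step is available, and a number 14.5 percentage points lower from compound 2 to compound 3 (beyond the scatter) is modest. It concerns a different place, with methyl in place of 3-(trifluoromethyl)phenyl on an amine nitrogen in a ring, and so offers no direct guide. Among the compounds with values here, no step at the chain carbon has been measured. The expectation therefore starts from compound 1 at 82.1% and anticipates no step beyond the scatter. The expected change is a number 4.1 percentage points lower from compound 1 to compound 4 (within the scatter) in this estimate. Compound 4 is expected at 78% in this assay with 60% to 91% as its estimated range.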

Compound 4, percent of the compound remaining: 81.6%
Estimate against measurement, compound 4: 3.6 percentage points below; the measured number falls inside the stated range.
By their numbers in this assay, from the lowest: compounds 3, 4, 1 and 2 (each within the scatter of the next, the first and the last beyond it).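

Putting cyclohexyl in place of cyclopropyl on a saturated chain carbon bound to an amine nitrogen gives, in this assay, a number 0.5 percentage points lower from compound 1 to compound 4 (within the scatter). Going by these compounds alone, this is the first reading at this position, and it shows that the six-membered carbon ring can stand where the three-membered one stood without a change beyond the scatter. Within the data shown here, the only earlier step, a number 14.5 percentage points lower from compound 2 to compound 3 (beyond the scatter), concerned an amine nitrogen in a ring, so it said nothing about this place. No measurement shown here offers an explanation for this result.

The compounds shown carry only carbon rings at this position, so it stays open whether a phenyl ring, or a cyclohexyl bearing a hydroxyl or an amine, would also stay within the scatter. On these data alone, it is also open whether the same swap would read alike with a substituted amine nitrogen in the ring, as in compound 2 and compound 3.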